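The source may hold more compounds than are shown below. What is called first, only, known or untested is meant among the compounds shown, and "the series" means these compounds.

Compound 1 `CC(C)C(=O)N1CC2CC(C1)N2` carries an isopropyl group on the carbonyl carbon of the shared core. Among the compounds with values here, in an assay on CHO cells for agonist activity at Neuronal acetylcholine receptor; alpha3/alpha6/beta2/beta3 (Homo sapiens), read by FLIPR and calcium flux (on this read-out lower numbers stand for an effect already at smaller amounts and higher numbers for an effect only at larger amounts of compound), compound 1 gives 16000 nM, the highest of the two numbers measured so far. Within the data shown here, the only comparator is compound 2 `O=C(C1CC=CC1)N1CC2CC(C1)N2`, which in this assay gives 1900 nM; its gap to compound 1 lies beyond the usual scatter, so the two compounds are clearly set apart on this read-out. Among the measured compounds shown here, no step between these two has been worked out, and they differ in more than one place, so only the two values themselves are on hand.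

Compound 3 `C[C@H]1C[C@H]1C(=O)N1CC2CC(C1)N2` has not been measured. It differs from compound 1 in one place: 2-methylcyclopropyl in place of isopropyl on a carbonyl carbon. With no listed step to lean on, the expected size of this change can only be guessed from what compound 1 and compound 2 show. A moderate move toward lower numbers is expected, the estimated step being a 3.2-fold lower number from compound 1 to compound 3 (0.51 log units; beyond the scatter). For compound 3 in this assay the estimate is 5000 nM, within a range of 1500 nM to 16000 nM.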

Compound 3, half-maximal effective concentration: 2000 nM
Compound 3: the middle estimate sits 2.5-fold (0.40 log units) above what was measured; the range from low to high includes it.
By their numbers in this assay, from the lowest: compounds 2 and 3 (each within the scatter of the next); then compound 1.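

This is the first step in the series read at a single place, so the group on the carbonyl carbon is shown to matter in this assay: 2-methylcyclopropyl in place of isopropyl gives an 8.0-fold lower number from compound 1 to compound 3 (0.90 log units; beyond the scatter). The change involves carbon alone, since the counts of hydrogen-bond donors and acceptors stay the same and neither group carries a net charge, so this read-out responds to a change in the carbon framework at this position. The step combines several differences at once, namely one added carbon, a three-membered ring and two defined stereocentres, and this single pair cannot separate their contributions, while nothing on hand accounts for the step.

Still open, from the compounds shown here alone, is which of those differences carries the step: plain cyclopropyl, tert-butyl and the other stereoisomers of 2-methylcyclopropyl on the same carbonyl carbon would begin to separate them. Also open, going by these compounds, is how far the trend extends at this position, whether to a longer chain such as n-pentyl or to a group of a different kind such as an amine or a carboxylic acid.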